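This account rests on a few compounds, and the source may have more. Where it says the series, first, only, none or still open, it means among the compounds named here.

Measured compounds:
compound 1 `CN(C)CCn1cnnc1-c1cc(Oc2ccc(NC(=O)N/N=C/c3cccc(Br)c3)cc2F)ccn1` gives 4230 nM in an ADME assay on WI-38 cells (Homo sapiens) for cytotoxicity, read by MTT assay, with a stated time of 72 h; a lower number here means a stronger inhibitor, a higher number a weaker inhibitor;
compound 2 `CN(C)CCn1cnnc1-c1cc(Oc2ccc(NC(=O)N/N=C/c3ccc(O)c(F)c3)cc2F)ccn1` gives "not determined" (no result reported) in this assay.

Compound 2 therefore stands nowhere on the numbers: no value was reported for it, so nothing can be placed against it. The step to compound 3 `CN(C)CCn1cnnc1-c1cc(Oc2ccc(NC(=O)N/N=C/c3c(Cl)cccc3Cl)cc2F)ccn1` changes the group on the carbon double-bonded to nitrogen: 2,6-dichlorophenyl in place of 3-fluoro-4-hydroxyphenyl on a carbon with a double bond to nitrogen. For the measured compounds named here, no measured step exists for this change, so its size and direction cannot be judged from the data. Going by the values given here, the only anchor is compound 1, which shares the core and gives 4230 nM. Compound 3 is expected to land near that anchor, estimated at 4000 nM with a range from 1300 nM to 12000 nM.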

Compound 3, half-maximal inhibitory concentration: 3320 nM
Compound 3: the middle estimate sits 1.2-fold (0.08 log units) above what was measured, and the stated range covers the measured number.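

Putting 2,6-dichlorophenyl in place of 3-bromophenyl on a carbon with a double bond to nitrogen gives a 1.3-fold lower number from compound 1 to compound 3 (0.11 log units; within the scatter) in this assay. This first readable comparison at this position shows that the two aromatic groups cannot be told apart in this cell test. No measurement here explains that result.

Steps involving compound 2 cannot be read, as it has no reported value. Going by these compounds, whether a phenyl ring carrying an amine or a carboxylic acid at this position would shift the number remains open.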